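A few compounds are considered here, and "the series" means these few. Any claim that something is new, unique, unknown or untested is made for them only; others in the source may bear on it.

Measured so far:
- compound 1, `Clc1ccc(Nc2cncc(N3CC4CC(C3)N4)c2)cc1`: 0.118 nM
- compound 2, `Clc1cccc(Nc2cncc(N3CC4CC(C3)N4)c2)c1`: 0.124 nM

Both compounds share the core and differ only in the chloro position on the aryl amine. In an assay on cell membranes for displacement of a labelled ligand from Neuronal acetylcholine receptor; alpha4/beta2 (Rattus norvegicus) (on this read-out lower numbers stand for stronger inhibition and higher numbers for weaker inhibition), compound 1 gives 0.118 nM and compound 2 gives 0.124 nM; the step of a 1.1-fold higher number from compound 1 to compound 2 (0.02 log units; within the scatter) is within the scatter, so compound 2 stands at the higher of the two numbers without any real separation from compound 1.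

The next compound, compound 3, `c1ccc(Nc2cncc(N3CC4CC(C3)N4)c2)cc1`, is not yet measured. Its change from compound 2 is hydrogen in place of chloro on an aromatic carbon, that is, 3-chlorophenyl to phenyl.

Among the measured compounds shown here, no measured step removes a chloro group; the only step known, from compound 1 to compound 2, moves it and shows nothing beyond the scatter. Loss of the halogen is therefore untested here. For the measured compounds named here, the expected step of a 2.4-fold higher number from compound 2 to compound 3 (0.38 log units; beyond the scatter) is a modest increase in the number, held with little confidence since the single measured step gives no bearing on it. Compound 3 is estimated at 0.3 nM in this assay, with a range from 0.1 nM to 1 nM.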

Compound 3, inhibition constant: 0.0807 nM
Estimate against measurement, compound 3: 3.7-fold (0.57 log units) above; the measured number lies below the stated range.
By their numbers in this assay, from the lowest: compounds 3, 1 and 2 (each within the scatter of the next).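

In this assay, hydrogen in place of chloro on the 3-chlorophenyl group gives a 1.5-fold lower number from compound 2 to compound 3 (0.19 log units; within the scatter), and the same replacement on the 4-chlorophenyl group gives a 1.5-fold lower number from compound 1 to compound 3 (0.17 log units; within the scatter), so both steps lie within the scatter. The earlier pair only moved the chloro group, whereas these two steps remove it and show that, across these three compounds, the phenyl compound is not separated from either chlorophenyl compound on this read-out. Nothing available accounts for this lack of separation.

Going by these compounds, the three compounds cover only hydrogen and chloro on the phenyl ring, so it remains open whether a methoxy group, a trifluoromethyl group, an amine or a carboxylic acid on that ring would move the number beyond the scatter. Equally open, on these data alone, is what an oxygen atom or a methylene link in place of the nitrogen joining the phenyl ring to the shared core would do to the number in this assay.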